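Aryl Ether Returns in Place of Isopropyl

A few compounds are considered here, and "the series" means these few. Any claim that something is new, unique, unknown or untested is made for them only; others in the source may bear on it.

The series shares one core, seen in compound 2 `C1=C(c2ccncc2)CC2CNCC1C2`, which in an in vitro assay on SH-EP1 cells for displacement of a labelled ligand from Neuronal acetylcholine receptor; alpha4/beta2 (Homo sapiens) (a lower number here means a stronger inhibitor, a higher number a weaker inhibitor), gives 56 nM. Adding an ether on the aromatic ring sharpens the numbers: compound 1 `COc1ccccc1Oc1cncc(C2=CC3CNCC(C2)C3)c1` gives 1 nM, and compound 3 `CC(C)Oc1cncc(C2=CC3CNCC(C2)C3)c1` gives 0.26 nM. Compound 3 stands at the lowest of the three numbers shown, with compound 1 nearest and compound 2 furthest. Among the measured compounds shown here, the only step measured in one place is a 3.8-fold lower number from compound 1 to compound 3 (0.59 log units; beyond the scatter).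

Compound 4 `Clc1cccc(Oc2cncc(C3=CC4CNCC(C3)C4)c2)c1` returns to an aryl ether: 3-chlorophenyl in place of isopropyl on an oxygen on an aromatic ring. The step from compound 1 to compound 3 bears directly on it, since that step ran from an aryl ether to the isopropyl ether and lowered the number. Reversing that direction, compound 4 is expected to show a 3.8-fold higher number from compound 3 to compound 4 (0.59 log units; beyond the scatter), a rise of about the size seen in the earlier step, though the two aryl groups differ. For compound 4 the estimated value is 1 nM, with a range from 0.3 nM to 3.5 nM.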

Compound 4, inhibition constant: 1 nM
Compound 4: middle estimate and measured number agree at the digits printed; low and high end bracket the measured number.
By their numbers in this assay, from the lowest: compound 3; then compounds 1 and 4 (each within the scatter of the next); then compound 2.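

In this assay, the step of a 3.8-fold higher number from compound 3 to compound 4 (0.59 log units; beyond the scatter) shows that the isopropyl ether's lower number is not confined to a comparison with 2-methoxyphenyl: both aryl ethers shown on this oxygen give a higher number than the isopropyl ether. The step of no change at the digits printed from compound 1 to compound 4 (within the scatter) shows that these two aryl groups cannot be told apart here, even though they carry different substituents, one a methoxy group and the other a chlorine. No evidence at hand accounts for these numbers.

The compounds shown leave open whether other small alkyl ethers, such as ethyl or cyclopropyl, would match the isopropyl ether. They also leave open whether an aryl ring carrying an amine or a carboxylic acid would stay level with the two aryl ethers.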